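The source may report more compounds than this note shows. Statements on the series, on what has been measured and on what is new or still open speak of the compounds shown alone.

Measured in a functional assay on DU-145 cells (Homo sapiens) for inhibition, read by trypan blue exclusion, with a stated time of 96 h; a lower number here means a stronger inhibitor of growth, a higher number a weaker inhibitor of growth:
- compound 1 `O=C(/C(=C\c1ccc(F)c([N+](=O)[O-])c1)S(=O)(=O)c1ccc(Br)cc1)c1ccc(Br)cc1`: 25000 nM
- compound 2 `O=C(/C(=C\c1csc([N+](=O)[O-])c1)S(=O)(=O)c1ccc(Br)cc1)c1ccc(Br)cc1`: 1000 nM
- compound 3 `O=C(/C(=C\c1ccc(I)cc1)S(=O)(=O)c1ccc(Br)cc1)c1ccc(Br)cc1`: 1000 nM

Compound 3, at 1000 nM, stands level with compound 2, and together they hold the lowest of the three numbers. Compound 1 lies well apart from them.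

Compound 4 `O=C(/C(=C\c1ccc(F)cc1F)S(=O)(=O)c1ccc(Br)cc1)c1ccc(Br)cc1` has 2,4-difluorophenyl in place of 4-iodophenyl on a double-bonded chain carbon bound to a double-bonded chain carbon.

All three measured steps concern this same place, and they disagree in size. The step of a 25-fold lower number from compound 1 to compound 3 (1.40 log units; beyond the scatter) is large, as is a 25-fold lower number from compound 1 to compound 2 (1.40 log units; beyond the scatter), whereas no change at the digits printed from compound 2 to compound 3 (within the scatter) lies within the scatter. So a change here can matter greatly in this assay or hardly at all. Within the data shown here, compound 1, with 4-fluoro-3-nitrophenyl at 25000 nM, is the only measured compound with fluorine on this group, and it is the one high value. That is thin evidence, since it also carries a nitro group, as does compound 2 at 1000 nM. Among the measured compounds shown here, no measured compound has 2,4-difluorophenyl, so only a small move towards a higher number is expected, not a large one. The expected change is a 2.5-fold higher number from compound 3 to compound 4 (0.40 log units; beyond the scatter). The estimate for compound 4 is 2500 nM, with an expected range from 500 nM to 12000 nM.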

Compound 4, concentration for 50% growth inhibition: 7500 nM
Estimate against measurement, compound 4: 3.0-fold (0.48 log units) below, within the range that was stated.
By their numbers in this assay, from the lowest: compounds 2 and 3 (each within the scatter of the next); then compound 4; then compound 1.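

In this assay, this place on a double-bonded chain carbon bound to a double-bonded chain carbon now shows a middle level rather than only two extremes: 2,4-difluorophenyl gives a 7.5-fold higher number from compound 3 to compound 4 (0.88 log units; beyond the scatter) and a 7.5-fold higher number from compound 2 to compound 4 (0.88 log units; beyond the scatter), yet still a 3.3-fold lower number from compound 1 to compound 4 (0.52 log units; beyond the scatter). Among these four compounds, the two with fluorine on this group, compound 1 and compound 4, hold the two highest numbers, and compound 4 stands apart from compound 2 and compound 3 without any nitro group; the nitro group itself shows no single trend, as compound 1 is high and compound 2 is low. Nothing at hand accounts for these differences in growth inhibition.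

The compounds shown do not separate the loss of iodine from the entry of fluorine, as the step from compound 3 to compound 4 makes both changes at once. Also open, as far as these compounds go, is how an amine or a carboxylic acid on this aromatic ring would compare, and whether these steps keep their size when the rest of the shared core is changed.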